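Sulfanyl or sulfonyl: estimating compound 4

This account rests on a few compounds, and the source may have more. Where it says the series, first, only, none or still open, it means among the compounds named here.

Compound 1 `O=C(/C(=C\c1ccc(O)c([N+](=O)[O-])c1)S(=O)(=O)Cc1ccc(Br)cc1)c1c(F)c(F)c(F)c(F)c1F`: 50000 nM
Compound 2 `COc1cc(OC)c(/C=C(/SCc2ccc(Cl)cc2)C(=O)c2ccc(Br)cc2)c(OC)c1`: 1000 nM
Compound 3 `COc1cc(OC)c(/C=C(\C(=O)c2ccc(Br)cc2)S(=O)(=O)Cc2ccc(Cl)cc2)c(OC)c1`: 25000 nM

All three values come from a functional assay on DU-145 cells (Homo sapiens) for inhibition, read by trypan blue exclusion, with a stated time of 96 h; a lower number here means a stronger inhibitor of growth, a higher number a weaker inhibitor of growth. Compound 3, at 25000 nM, lies within the scatter of compound 1 and far above compound 2. Compound 4 `COc1cc(OC)c(/C=C(/SCc2ccc(F)cc2)C(=O)c2ccc(Br)cc2)c(OC)c1` differs from compound 3 by (4-fluorobenzyl)sulfanyl in place of (4-chlorobenzyl)sulfonyl on a double-bonded chain carbon bound to a carbonyl carbon and a double-bonded chain carbon: (4-fluorobenzyl)sulfanyl in place of (4-chlorobenzyl)sulfonyl, on a double-bonded chain carbon bound to a carbonyl carbon and a double-bonded chain carbon. The nearest evidence is the large step of a 25-fold higher number from compound 2 to compound 3 (1.40 log units; beyond the scatter), which went the opposite way, from sulfanyl to sulfonyl. Within the data shown here, no measured step covers the exchange of chlorine for fluorine. In this assay a large fall is therefore expected, an estimated 19-fold lower number from compound 3 to compound 4 (1.28 log units; beyond the scatter). For compound 4 the estimated value is 1300 nM, with an expected range of 350 nM to 5000 nM.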

Compound 4, concentration for 50% growth inhibition: 1000 nM
Beside the measured number, compound 4's estimate is 1.3-fold (0.11 log units) above it; the range from low to high includes it.
By their numbers in this assay, from the lowest: compounds 2 and 4 (each within the scatter of the next); then compounds 3 and 1 (each within the scatter of the next).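

In this assay, the exchange of chlorine for fluorine, unmeasured until now, proved silent on the sulfanyl series, with no change at the digits printed from compound 2 to compound 4 (within the scatter). The large fall, a 25-fold lower number from compound 3 to compound 4 (1.40 log units; beyond the scatter), is therefore matched in size by the earlier sulfanyl-to-sulfonyl step, and the halogen exchange adds nothing visible to it. No measurement shown explains why the sulfur group matters so strongly here.

From the compounds shown here alone, whether fluoro and chloro would also match on a sulfonyl compound remains open. So does how a sulfinyl group at that carbon, or an amine in place of the halogen, would read.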